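The source may report more compounds than this note shows. Statements on the series, on what has been measured and on what is new or still open speak of the compounds shown alone.

Measured so far:
Compound 1 `COc1cc(Nc2ncc(C(F)(F)F)c(N3Cc4cccc(N(C)S(C)(=O)=O)c4C3)n2)c(OC)cc1Cl`: 6200 nM
Compound 2 `CN(c1cccc2c1CN(c1nc(Nc3ccc(C(F)(F)F)cc3)ncc1C(F)(F)F)C2)S(C)(=O)=O`: > 30000 nM

In a functional assay on U-87MG ATCC cells for antiproliferative activity against U-87 MG (Homo sapiens), read by spectrophotometry, with a stated time of 2 days (a lower number here means a stronger inhibitor of growth, a higher number a weaker inhibitor of growth), compound 2 gives > 30000 nM, which is a limit and not a number. It stands at the limit of > 30000 nM in this assay, at which 1 of the 2 values shown sits. Going by the values given here, the one measured step is an at least 4.8-fold higher number from compound 1 to compound 2 (0.68 log units; beyond the scatter), where 4-(trifluoromethyl)phenyl took the place of 4-chloro-2,5-dimethoxyphenyl on a nitrogen on an aromatic ring.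

Compound 3 `COc1cc(Nc2ncc(C(F)(F)F)c(N3Cc4cccc(N(C)S(C)(=O)=O)c4C3)n2)cc(OC)c1` keeps the shared core and differs from compound 2 in one place: 3,5-dimethoxyphenyl in place of 4-(trifluoromethyl)phenyl on a nitrogen on an aromatic ring. That measured step bears on this one when read in reverse, since compound 3 also gives up 4-(trifluoromethyl)phenyl for a dimethoxyphenyl group. The match is only partial, however, as 3,5-dimethoxyphenyl has no chloro group and its methoxy groups are numbered differently. A move to a lower number is therefore expected in this assay, towards compound 1 at 6200 nM. From the compounds shown here alone, the size of that move stays open, as compound 2 is known only as a limit. The expected change is an at least 2.5-fold lower number from compound 2 to compound 3 (0.39 log units; beyond the scatter). Compound 3 is estimated at 12000 nM, with an expected range from 4500 nM to 30000 nM.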

Compound 3, concentration for 50% growth inhibition: > 30000 nM
Compound 3 was reported as a limit (the forecaster's own chance of this, stated with the estimate: 30%); at least 2.5-fold (0.39 log units) between middle value and limit.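

In this assay, 3,5-dimethoxyphenyl in place of 4-chloro-2,5-dimethoxyphenyl on a nitrogen on an aromatic ring gives an at least 4.8-fold higher number from compound 1 to compound 3 (0.68 log units; beyond the scatter), so among these compounds, carrying two methoxy groups on the phenyl ring does not by itself keep the level of compound 1, and the loss is no longer confined to 4-(trifluoromethyl)phenyl. Compound 1, at 6200 nM, remains the only one of the three with a number rather than a limit. The step from compound 2 to compound 3 cannot be read, and no order can be given between them, because both stand at a limit: the limit of > 30000 nM in this assay, at which 2 of the 3 values shown sit.

The compounds shown leave open whether the chloro group or the arrangement of the methoxy groups separates compound 1 from compound 3, as that one step changes both at once. They also leave open how a phenyl ring carrying a bromo group or a morpholine, attached at this same nitrogen on the shared core, would read in this assay.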